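Ring size at the chain end: a change without a precedent

A few compounds are considered here, and "the series" means these few. Any claim that something is new, unique, unknown or untested is made for them only; others in the source may bear on it.

Measured so far:
compound 1, `COc1cc2c(Nc3nc4ccc(C(=O)Nc5c(C)cc(C)cc5C)cc4s3)ncnc2cc1OCCCN1CCC(C)CC1`: 5600 nM
compound 2, `COc1cc2c(Nc3nc4ccc(C(=O)Nc5c(C)cccc5Cl)cc4s3)ncnc2cc1OCCCN1CCCC1`: 19900 nM
compound 3, `COc1cc2c(Nc3nc4ccc(C(=O)Nc5c(C)cc(C)cc5C)cc4s3)ncnc2cc1OCCCN1CCCCC1`: 12200 nM

All three numbers come from a functional assay on U-937 cells (Homo sapiens) for cytotoxicity, read by WST assay, with a stated time of 72 h; on this read-out higher numbers stand for weaker inhibition and lower numbers for stronger inhibition. Compound 3 stands apart from compound 1 by a step that is beyond the scatter, a 2.2-fold higher number from compound 1 to compound 3 (0.34 log units; beyond the scatter), whereas the gap between compound 3 and compound 2 lies within the scatter, so those two can only be set side by side without any order between them.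

Compound 4, `COc1cc2c(Nc3nc4ccc(C(=O)Nc5c(C)cc(C)cc5C)cc4s3)ncnc2cc1OCCCN1CCCC1`, differs from compound 3 in one place: pyrrolidin-1-yl in place of piperidin-1-yl on a saturated chain carbon, three bonds along the chain from an oxygen on an aromatic ring. For the measured compounds named here, no measured pair makes this change on its own. Compound 2 does carry the pyrrolidin-1-yl ring, but it also bears a different amide aryl group, so its value and that of compound 3 say nothing clean about the ring alone. Going by the values given here, the only step measured, a 2.2-fold higher number from compound 1 to compound 3 (0.34 log units; beyond the scatter), concerns a methyl on the saturated ring and not the ring's size, and it was modest. Among the compounds with values here, with no direct precedent, the step from compound 3 to compound 4 is expected to stay within the scatter, a 1.1-fold higher number from compound 3 to compound 4 (0.06 log units; within the scatter), with a wide range allowed. Compound 4 is therefore expected to give about 14000 nM, with a range from 6000 nM to 35000 nM.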

Compound 4, half-maximal inhibitory concentration: 4600 nM
Estimate against measurement, compound 4: 3.0-fold (0.48 log units) above; the measured number lies below the stated range.
By their numbers in this assay, from the lowest: compounds 4 and 1 (each within the scatter of the next); then compounds 3 and 2 (each within the scatter of the next).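

In this assay the ring at the end of the chain can now be read on its own: a 2.7-fold lower number from compound 3 to compound 4 (0.42 log units; beyond the scatter) is the effect of pyrrolidin-1-yl in place of piperidin-1-yl on a saturated chain carbon, three bonds along the chain from an oxygen on an aromatic ring, so this position does respond to ring size. For the compounds shown here, with the pyrrolidin-1-yl ring held fixed, a 4.3-fold lower number from compound 2 to compound 4 (0.64 log units; beyond the scatter) adds a first clean reading at the other end of the molecule, where 2,4,6-trimethylphenyl stands in place of 2-chloro-6-methylphenyl on an amide-type nitrogen. The chain-end rings of the two lowest numbers cannot be put in order, since a 1.2-fold lower number from compound 1 to compound 4 (0.09 log units; within the scatter) leaves pyrrolidin-1-yl and 4-methylpiperidin-1-yl side by side, while the plain piperidin-1-yl of compound 3 gives a higher number than either.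

The compounds shown leave open how a morpholin-4-yl ring or a dimethylamino group would behave at the end of the chain, and whether a butyl linker in place of the propyl chain would keep these numbers. Nothing at hand offers an explanation for any of these steps.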